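The source may report more compounds than this note shows. Statements on the series, on what has been measured and on what is new or still open speak of the compounds shown alone.

Measured in a functional assay on MDA-MB-436 cells (Homo sapiens) for cytotoxicity, read by fluorescence and resazurin assay, with a stated time of 72 h; a higher number here means a weaker inhibitor, a lower number a stronger inhibitor:
- Compound 1 `Nc1nc(Nc2ccc(S(N)(=O)=O)cc2)sc1C(=O)c1ccccc1[N+](=O)[O-]`: 2000 nM
- Compound 2 `Nc1nc(Nc2ccc(S(N)(=O)=O)cc2)sc1C(=O)c1cccc(F)c1`: 1300 nM
- Compound 3 `Nc1nc(Nc2ccc(S(N)(=O)=O)cc2)sc1C(=O)c1ccc(S(N)(=O)=O)cc1`: > 10000 nM

Only two of these three results are numbers. Compound 2, at 1300 nM, stands within the scatter of compound 1, at 2000 nM. The reading for compound 3 is > 10000 nM, which is a limit of the assay and not a number.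

The account now turns to compound 4 `Nc1cccc(C(=O)c2sc(Nc3ccc(S(N)(=O)=O)cc3)nc2N)c1`, which has not yet been measured in this assay. It differs from compound 2 by amino in place of fluoro on an aromatic carbon, meta to a large group: amino in place of fluoro on an aromatic carbon.

Among the compounds with values here, no measured pair shows this exchange directly. Within the data shown here, the nearest evidence is the one measured step, where 3-fluorophenyl takes the place of 2-nitrophenyl on a carbonyl carbon: a 1.5-fold lower number from compound 1 to compound 2 (0.19 log units; within the scatter). That step stayed within the scatter, although the change was at the same part of the molecule. On that basis, no step beyond the scatter is expected in this assay, though the evidence is thin and the range is kept wide. The estimate amounts to a 1.2-fold higher number from compound 2 to compound 4 (0.06 log units; within the scatter), which is the expected step. For compound 4 the estimated value is 1500 nM, with an expected range from 500 nM to 5000 nM.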

Compound 4, half-maximal inhibitory concentration: > 10000 nM
Compound 4: a limit, no number; the forecaster's own chance of this, stated with the estimate: 10%; at least 6.6-fold (0.82 log units) between middle value and limit.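

In this assay, the reading for compound 4, > 10000 nM, is a limit of the assay and not a number. Within the data shown here, the one earlier step on this ring, a 1.5-fold lower number from compound 1 to compound 2 (0.19 log units; within the scatter), had left open whether a change here could matter at all in these cells, whereas the exchange of 3-fluorophenyl for 3-aminophenyl gives an at least 7.6-fold higher number from compound 2 to compound 4 (0.88 log units; beyond the scatter), and the comparison with the nitro compound gives an at least 5.0-fold higher number from compound 1 to compound 4 (0.69 log units; beyond the scatter), so a single-atom exchange at this aromatic carbon is enough to carry the number beyond the scatter. Both steps give only a minimum size, and the full size of the change cannot be read: the limit of > 10000 nM in this assay, at which 2 of the 4 values shown sit.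

The compounds shown leave open whether this step belongs to the amino group in particular or would also follow from other groups on the same aromatic carbon, such as a hydroxyl, a methoxy or a chloro group. They also leave open whether an amine carrying a methyl or an acetyl group would give a number inside the range of the assay, which would put a size on the change.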